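Chloro in Place of Fluoro, Tried in a Second Pair

This account rests on a few compounds, and the source may have more. Where it says the series, first, only, none or still open, it means among the compounds named here.

Measured compounds:
compound 1, `Nc1ccccc1NC(=O)/C=C/c1ccc(CSc2ccc(Cl)cc2)cc1`: 13.4%
compound 2, `Nc1ccccc1NC(=O)/C=C/c1ccc(CSc2ccc(F)cc2)cc1`: 28.8%
compound 3, `Nc1ccccc1NC(=O)c1ccc(CSc2ccc(F)cc2)cc1`: 19.4%

In a functional assay on A-375 cells (Homo sapiens) for inhibition, read by CCK-8 assay, with a stated time of 72 h, tested at 2 uM (a lower number here means less inhibition of growth, a higher number more inhibition of growth at the concentration tested), compound 2 gives 28.8%, and compound 1 gives 13.4%. The change between them is chloro in place of fluoro on an aromatic carbon and it makes a number 15.4 percentage points lower from compound 2 to compound 1 (beyond the scatter). Compound 3 gives 19.4% in this assay; its value and that of compound 1 lie within the scatter of each other, and so do its value and that of compound 2. The difference between the core of compound 3 and the core of compound 2 is not broken down here.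

Compound 4, `Nc1ccccc1NC(=O)c1ccc(CSc2ccc(Cl)cc2)cc1`, has not yet been measured. Within the data shown here, it differs from compound 3 by chloro in place of fluoro on an aromatic carbon, the same change as the one made from compound 2 to compound 1, at a place described in the same words. Compound 4 is therefore expected to give 7%, somewhere between 0% and 22%, because the earlier pair showed a number 15.4 percentage points lower from compound 2 to compound 1 (beyond the scatter). The step from compound 3 is expected to be a number 12.4 percentage points lower from compound 3 to compound 4 (beyond the scatter), though a single earlier pair is thin ground, and the two cores differ.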

Compound 4, percent growth inhibition at one concentration: 25.3%
Beside the measured number, compound 4's estimate is 18.3 percentage points below it; the measured number lies above the stated range.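

In this assay, chloro in place of fluoro on the other core gives a number 5.9 percentage points higher from compound 3 to compound 4 (within the scatter), so the clear fall seen on the first core does not recur. Set side by side, the two steps disagree: the same change on two cores in this assay, a number 15.4 percentage points lower (beyond the scatter) from compound 2 to compound 1 and a number 5.9 percentage points higher (within the scatter) from compound 3 to compound 4, 21.3 percentage points apart, beyond the scatter of two such steps This shows that the size of this change on one core could not be carried over to the other in this series; it does not show a reversal, as the new step lies within the scatter, and with one pair on each core it offers no explanation for the disagreement.

The compounds shown leave open whether the disagreement is peculiar to fluoro and chloro, the only two groups that appear at this place. A bromo or methoxy group, or an amine, on that aromatic carbon of both cores would show whether other changes also part ways between the cores or carry across.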